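A few compounds are considered here, and "the series" means these few. Any claim that something is new, unique, unknown or untested is made for them only; others in the source may bear on it.

Compound 1, `O=C(CC1c2ccccc2N=C(SCCCCCN2CCCC2)N1c1ccc(-c2ccccc2)cc1)NCc1ccc(F)cc1`, gives 6200 nM in a functional assay on HCT-116 cells (Homo sapiens) for cytotoxicity, read by MTT assay, with a stated time of 48 h; a lower number here means a stronger inhibitor, a higher number a weaker inhibitor. Compound 2, `O=C(CC1c2ccccc2N=C(SCCCCCN2CCCC2)N1c1ccccc1)NCc1ccc(F)cc1`, gives 27100 nM in this assay.

Going by the values given here, compound 1 thus holds the lower of the two numbers measured in this assay; the only measured step, a 4.4-fold higher number from compound 1 to compound 2 (0.64 log units; beyond the scatter), concerns hydrogen in place of phenyl on an aromatic carbon and so touches a different part of the shared core. The unmeasured compound 3, `CN(C)CCCCCSC1=Nc2ccccc2C(CC(=O)NCc2ccc(F)cc2)N1c1ccc(-c2ccccc2)cc1`, differs from compound 1 by dimethylamino in place of pyrrolidin-1-yl on a saturated chain carbon, five bonds along the chain from a sulfur. Among the compounds with values here, no measured step bears on a change at this part of the chain, so the account can lean on nothing but the value of compound 1 itself. The step is therefore expected to stay within the scatter, with a 1.1-fold higher number from compound 1 to compound 3 (0.05 log units; within the scatter) as the estimated change. For compound 3 the expected result in this assay is 7000 nM, with a range from 3000 nM to 17000 nM.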

Compound 3, half-maximal inhibitory concentration: 6400 nM
Beside the measured number, compound 3's estimate is 1.1-fold (0.04 log units) above it; the range from low to high includes it.
By their numbers in this assay, from the lowest: compounds 1 and 3 (each within the scatter of the next); then compound 2.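

In this assay, the change at the end of the chain gives a 1.0-fold higher number from compound 1 to compound 3 (0.01 log units; within the scatter), so dimethylamino and pyrrolidin-1-yl cannot be told apart at this position on the shared core. This shows that, in this pair, the five-membered non-aromatic ring can give way to an open dimethylamino group with no change beyond the scatter, whereas the earlier step spoke only to the phenyl group on an aromatic carbon. Nothing at hand offers an explanation for this result.

The compounds shown leave open whether the same holds on the core of compound 2, which carries hydrogen in place of that phenyl group. They also leave open how a morpholine, a primary amine, a hydroxyl group or a shorter chain would read at this end of the molecule.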